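Extending a Chain on Two Related Cores

The source may report more compounds than this note shows. Statements on the series, on what has been measured and on what is new or still open speak of the compounds shown alone.

Of the compounds shown here, three have been tested so far in an assay on HEK293 cells for inhibition of solute carrier family 12 member 2 (Homo sapiens), read by fluorescence, with a stated time of 30 min, tested at 100 uM; on this read-out higher numbers stand for a stronger effect at the one concentration tested and lower numbers for a weaker effect. Compound 1 `CCCCNc1ccc([N+](=O)[O-])cc1S(N)(=O)=O` gives 4.7%. Compound 2 `CCCCCCCCNc1ccc([N+](=O)[O-])cc1S(N)(=O)=O` differs from compound 1 by butyl in place of hydrogen on a saturated chain carbon, four bonds along the chain from a nitrogen on an aromatic ring, and compound 2 gives 5.8%; this amounts to a number 1.1 percentage points higher from compound 1 to compound 2 (within the scatter), so the longer chain made no difference that can be told apart from the noise of the measurement. Compound 3 `CCCCNc1ccc(C(=O)O)cc1S(=O)(=O)NC` gives 6.2%; the difference between the core of compound 3 and the core of compound 1 is not broken down here, and all three values sit close together, with none standing apart from the others.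

Compound 4 `CCCCCCCCNc1ccc(C(=O)O)cc1S(=O)(=O)NC` has not been measured. It differs from compound 3 by butyl in place of hydrogen on a saturated chain carbon, four bonds along the chain from a nitrogen on an aromatic ring, the same change that turns compound 1 into compound 2. Because that earlier change gave only a number 1.1 percentage points higher from compound 1 to compound 2 (within the scatter), the step from compound 3 to compound 4 is expected to be of a similar size, about a number 1.1 percentage points higher from compound 3 to compound 4 (within the scatter). On that basis compound 4 is estimated to give 7.3% in this assay, with a plausible range from -3% to 17%.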

Compound 4, a percentage reported as inhibition, at one concentration (the size of the read-out at that concentration, not a potency): 20.1%
For compound 4 the middle estimate is 12.8 percentage points below the measured one, and the stated range ends below it.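

In this assay, butyl in place of hydrogen on the chain brings a number 13.9 percentage points higher from compound 3 to compound 4 (beyond the scatter), a step that on its own stands clear of the noise. Set beside the same change on the core of compound 1, however, the two steps cannot be told apart: the same change on two cores in this assay, a number 1.1 percentage points higher (within the scatter) from compound 1 to compound 2 and a number 13.9 percentage points higher (beyond the scatter) from compound 3 to compound 4, 12.8 percentage points apart, within the scatter of two such steps. This does not show that the core decides how much the longer chain adds, nor does it prove that the change carries over unaltered, since one step on each core is too little to settle either reading.

The compounds shown leave open what a still longer chain, or a phenyl ring at the end of the chain, would do on either core. They also leave open which part of the core would matter if the two steps did turn out to differ, as the core of compound 1 and the core of compound 3 differ in more than one place.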